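A few compounds are considered here, and "the series" means these few. Any claim that something is new, unique, unknown or untested is made for them only; others in the source may bear on it.

Compound 3 `COc1ccc(-c2nc(SC)nc(NCCCCNc3ccnc4cc(Cl)ccc34)c2C#N)cc1` sits in an ADME assay on MDCK cells (Canis lupus familiaris) for cytotoxicity, read by microscopy (a lower number here means that less compound is tolerated, a higher number that more compound is tolerated), at 20000 nM. Its nearest neighbour is compound 1 `CSc1nc(NCCCCNc2ccnc3cc(Cl)ccc23)c(C#N)c(-c2ccccc2)n1`, which in this assay gives 20000 nM; the step of no change at the digits printed from compound 1 to compound 3 (within the scatter), methoxy in place of hydrogen on an aromatic carbon, leaves the reading where it was. Compound 2 `CSc1nc(-c2ccccc2)c(C#N)c(N2CCN(c3ccnc4cc(Cl)ccc34)CC2)n1` stands apart, with a reading in this assay of > 100000 nM, which is a limit of the assay rather than a number (the limit of > 100000 nM in this assay, at which 1 of the 3 values shown sits). Compound 4 `CSc1nc(NCCCCNc2ccnc3cc(Cl)ccc23)c(C#N)c(-c2ccc(C)cc2)n1` has not yet been measured. It differs from compound 3 at one place: methyl in place of methoxy on an aromatic carbon. Within the data shown here, no measured step tries this exchange. Among the measured compounds shown here, the one step that touches the same aromatic carbon, from hydrogen to methoxy, lay within the scatter, so there is no sign so far that a substituent there moves the reading in this assay. Compound 4 is therefore expected to stay level with compound 3, and the expected step of no change at the digits printed from compound 3 to compound 4 (within the scatter) is no change beyond the scatter. Compound 4 is estimated at 20000 nM in this assay, with a range from 10000 nM to 40000 nM.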

Compound 4, minimum cytotoxic concentration: 20000 nM
For compound 4 middle estimate and measured number coincide at the digits printed; measured number inside the range.
By their numbers in this assay, from the lowest: compounds 1, 3 and 4 (each within the scatter of the next). At a limit, above all of these: compound 2.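

In this assay, among these compounds, the aromatic carbon para to a large group had so far carried only hydrogen and methoxy; it now carries a third group, methyl, and the direct exchange of 4-methoxyphenyl to 4-methylphenyl gives no change at the digits printed from compound 3 to compound 4 (within the scatter). Set against hydrogen on the same carbon, methyl gives no change at the digits printed from compound 1 to compound 4 (within the scatter), so compound 1, compound 3 and compound 4 stand level, and the reading holds whether the group there has a hydrogen-bond acceptor, as methoxy has, or none, as methyl has. Nothing measured here says why these three readings coincide.

The compounds shown leave open whether a group of another kind on this carbon, such as an amine or a carboxylic acid, would also leave the reading level with compound 1, and whether methoxy or methyl on another carbon of the same ring would do so. Among the compounds shown here, they also leave open how a longer chain in place of the one in compound 1 would read in this assay.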